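Second chloro on the aryl ring of compound 3

The compounds below may be only part of what the source reports. "The series", "measured", "known", "first", "only" and "open" are said of these compounds alone.

Among the measured compounds shown here, compound 3 `O=CN1CCN(c2ccc(Cl)cc2)C1=S` gives 15600 nM in a functional assay on OVCAR-8 cells (Homo sapiens) for inhibition, read by sulforhodamine B assay, with a stated time of 48 h (on this read-out higher numbers stand for weaker inhibition of growth and lower numbers for stronger inhibition of growth), the lowest of the three numbers so far, though compound 2 `N#C/C(=C\N1CCN(C(=O)c2ccco2)C1=S)C(=O)c1ccccc1` with 25400 nM sits within the scatter of it, and only compound 1 `N#C/C(=C\N1CCN(C(=O)c2ccco2)C1=S)C(N)=O` with 43600 nM sits beyond it. For the measured compounds named here, the single step between measured compounds that differ in one place, a 1.7-fold lower number from compound 1 to compound 2 (0.23 log units; within the scatter), concerns phenyl in place of amino on a carbonyl carbon and is within the scatter. Compound 4 `O=CN1CCN(c2ccc(Cl)c(Cl)c2)C1=S` differs from compound 3 by chloro in place of hydrogen on an aromatic carbon. Going by the values given here, no measured pair bears on a chloro added to this aromatic ring; the one step available concerns another part of the series and was within the scatter, so it gives no direction. No step beyond the scatter is therefore expected in this assay, and the expected step is a 1.3-fold lower number from compound 3 to compound 4 (0.11 log units; within the scatter). For compound 4 a value of about 12000 nM is estimated, with a range from 5000 nM to 30000 nM.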

Compound 4, concentration for 50% growth inhibition: 15000 nM
Compound 4: the middle estimate sits 1.3-fold (0.10 log units) below what was measured, and the stated range covers the measured number.
By their numbers in this assay, from the lowest: compounds 4, 3, 2 and 1 (each within the scatter of the next, the first and the last beyond it).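

In this assay, a chloro entering ortho to a chloro group and meta to a group of 8 heavy atoms gives a 1.0-fold lower number from compound 3 to compound 4 (0.02 log units; within the scatter). Among the compounds shown here, this is the first measured pair to bear on the aryl ring, and it shows that this position accepts a second chloro without a step that can be told from the scatter, so the added chlorine gives no gain or loss of growth inhibition here. No measurement at hand offers an explanation for this result.

The compounds shown leave open what an amine, a carboxylic acid or a longer chain would give on this same carbon, and what the aryl ring would give with hydrogen in place of both chloro groups. Also open, going by these compounds, is whether a chloro step would read the same on the core of compound 2.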